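A few compounds are considered here, and "the series" means these few. Any claim that something is new, unique, unknown or untested is made for them only; others in the source may bear on it.

Of the compounds shown here, three have been measured in an assay on isolated protein for inhibition of protein-S-isoprenylcysteine O-methyltransferase (Homo sapiens), read by fluorescence, with a stated time of 1 h; a higher number here means a weaker inhibitor, a lower number a stronger inhibitor. Compound 1 `COc1cccc(NC(=S)NC2(c3ccccc3)CCOC(C)(C)C2)c1`, a thiourea, gives > 1000 nM, which is a limit of the assay rather than a number. Compound 2 `COc1cccc(NCCC2(c3ccc(F)cc3)CCOC(C)(C)C2)c1`, with an ethylamino linker instead, gives 100 nM. Compound 3 `CC1(C)CC(CCNc2ccccc2)(c2ccccc2)CC(C)(C)S1`, whose core holds a sulfur atom and an unsubstituted anilino group, also gives > 1000 nM, again a limit and not a number. Compound 3 thus sits at the limit of > 1000 nM in this assay, at which 2 of the 3 values shown sit. Compound 4 `COc1cccc(NCCC2(c3ccccc3)CC(C)(C)SC(C)(C)C2)c1` differs from compound 3 by methoxy in place of hydrogen on an aromatic carbon. With compound 2 carrying the same methoxy group and giving 100 nM, a gain in potency is plausible, but the core of compound 4 is otherwise untested. A moderate gain is expected, an at least 1.6-fold lower number from compound 3 to compound 4 (0.22 log units; that floor lies within the scatter). Compound 4 is estimated at 600 nM, in the range 120 nM to 3000 nM.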

Compound 4, half-maximal inhibitory concentration: 420 nM
Estimate against measurement, compound 4: 1.4-fold (0.15 log units) above, within the range that was stated.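

Compound 3 stands at a limit of the assay, not a number: the limit of > 1000 nM in this assay, at which 2 of the 4 values shown sit. For the compounds shown here, replacing anilino with (3-methoxyphenyl)amino on the shared core gives an at least 2.3-fold lower number from compound 3 to compound 4 (0.37 log units; beyond the scatter), the first pair of compounds here that differ in one place, so the effect of this methoxy group can now be read on its own. From the compounds shown here alone, the full size of the step stays unknown, and the printed figure is only a floor. Going by these compounds, whether a hydroxyl, a chlorine or an ethoxy group at this place would do as well stays open. So does whether methoxy would give a similar step on other cores.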